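The source may hold more compounds than are shown below. What is called first, only, known or untested is meant among the compounds shown, and "the series" means these compounds.

Compound 1 `FC(F)(F)c1ccc(CN2CCN(Cc3cc(-c4ccc(OCc5ccccc5)cc4)on3)CC2)cc1` gives 11700 nM in a functional assay on Mahlavu cells (Homo sapiens) for antiproliferative activity, read by sulforhodamine B assay, with a stated time of 72 h; on this read-out higher numbers stand for weaker inhibition and lower numbers for stronger inhibition. Compound 2 `Cc1cccc(COc2ccc(-c3cc(CN4CCN(Cc5ccc(C(F)(F)F)cc5)CC4)no3)cc2)c1` gives 2500 nM in this assay, and compound 3 `FC(F)(F)c1ccc(CN2CCN(Cc3cc(-c4ccc(OCc5cccc(Cl)c5)cc4)on3)CC2)cc1` gives 4100 nM. On these numbers compound 3 lies beyond the scatter below compound 1 but within the scatter of compound 2. The steps read a 4.7-fold lower number from compound 1 to compound 2 (0.67 log units; beyond the scatter), a 2.9-fold lower number from compound 1 to compound 3 (0.46 log units; beyond the scatter) and a 1.6-fold higher number from compound 2 to compound 3 (0.21 log units; within the scatter). Compound 4 `N#Cc1cccc(COc2ccc(-c3cc(CN4CCN(Cc5ccc(C(F)(F)F)cc5)CC4)no3)cc2)c1` differs from compound 3 by cyano in place of chloro on an aromatic carbon. Going by the values given here, no measured step involves a cyano group; the two exchanges at the same aromatic carbon, a 2.9-fold lower number from compound 1 to compound 3 (0.46 log units; beyond the scatter) and a 1.6-fold higher number from compound 2 to compound 3 (0.21 log units; within the scatter), were modest or within the scatter, so a step within the scatter is expected. For compound 4 the expected step is a 1.2-fold higher number from compound 3 to compound 4 (0.09 log units; within the scatter). The estimate for compound 4 is 5000 nM, in a range from 2000 nM to 13000 nM.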

Compound 4, half-maximal inhibitory concentration: 10600 nM
Compound 4: middle estimate off by 2.1-fold (0.33 log units), on the low side; the range from low to high includes it.
By their numbers in this assay, from the lowest: compounds 2 and 3 (each within the scatter of the next); then compounds 4 and 1 (each within the scatter of the next).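

Cyano is the first group at this aromatic carbon, meta to a large group, whose number in this assay stays within the scatter of the unsubstituted compound (a 1.1-fold lower number from compound 1 to compound 4 (0.04 log units; within the scatter)). Chloro and methyl both lay beyond the scatter below hydrogen, and cyano separates from both (a 2.6-fold higher number from compound 3 to compound 4 (0.41 log units; beyond the scatter); a 4.2-fold higher number from compound 2 to compound 4 (0.63 log units; beyond the scatter)), so the earlier gains do not extend to every substituent here. No measured evidence accounts for this split.

Going by these compounds, whether it is specific to cyano remains open; a methoxy group, an amine or a carboxylic acid at this carbon would test that. On these data alone, whether the same order holds elsewhere on this ring also remains open.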